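Compound 4: fluoro in place of methyl

The source may report more compounds than this note shows. Statements on the series, on what has been measured and on what is new or still open speak of the compounds shown alone.

Values in a functional assay on HT-29 cells (Homo sapiens) for antiproliferative activity, read by sulforhodamine B assay, with a stated time of 48 h (on this read-out lower numbers stand for stronger inhibition and higher numbers for weaker inhibition), are as follows.
- Compound 1 `CN1CCN(c2ccc(S(=O)(=O)Oc3cccc(F)c3)cc2)C1=O` gives > 100000 nM as a limit.
- Compound 2 `CCCN1CCN(c2ccc(S(=O)(=O)Oc3c(Cl)cc(Cl)cc3Cl)cc2)C1=O` gives 56000 nM as a number.
- Compound 3 `CCCN1CCN(c2ccc(S(=O)(=O)Oc3cccc(C)c3)cc2)C1=O` gives 65000 nM as a number.
- Compound 4 `CCCN1CCN(c2ccc(S(=O)(=O)Oc3cccc(F)c3)cc2)C1=O` is not yet measured.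

Among the compounds with values here, compound 3 and compound 2 hold the only two numbers so far and lie within the scatter of each other. Compound 4 carries fluoro in place of methyl on an aromatic carbon, meta to a large group fluoro in place of methyl on an aromatic carbon in the same molecule. Within the data shown here, the one measured step at this group, 3-methylphenyl in place of 2,4,6-trichlorophenyl, is a 1.2-fold higher number from compound 2 to compound 3 (0.06 log units; within the scatter) and stays small. No step beyond the scatter is therefore expected in this assay here. The expected step is a 1.1-fold lower number from compound 3 to compound 4 (0.03 log units; within the scatter) on this estimate. Compound 4 could still meet the limit of > 100000 nM in this assay, at which 1 of the 3 values shown sits, in this read-out. For compound 4 the estimated value is 60000 nM with an expected range of 30000 nM to 100000 nM around it.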

Compound 4, half-maximal inhibitory concentration: 18000 nM
For compound 4 the middle estimate is 3.3-fold (0.52 log units) above the measured one, and the stated range ends above it.
By their numbers in this assay, from the lowest: compound 4; then compounds 2 and 3 (each within the scatter of the next). At a limit, above all of these: compound 1.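

In this assay, the aryl group on the oxygen does matter, since 3-fluorophenyl separates from the other two groups: fluoro in place of methyl gives a 3.6-fold lower number from compound 3 to compound 4 (0.56 log units; beyond the scatter), and 3-fluorophenyl in place of 2,4,6-trichlorophenyl gives a 3.1-fold lower number from compound 2 to compound 4 (0.49 log units; beyond the scatter). With ethyl in place of hydrogen on the chain carbon bound to the amide-type nitrogen in the ring, the step is an at least 5.5-fold lower number from compound 1 to compound 4 (0.74 log units; beyond the scatter). Compound 1 stands at a limit, so this step has no exact size: the limit of > 100000 nM in this assay, at which 1 of the 4 values shown sits.

Open, from the compounds shown here alone, is how chloro, methoxy or an amine at this place would compare with fluoro. Also open, going by these compounds, is whether a longer chain on the ring nitrogen would bring the number lower still.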